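This account rests on a few compounds, and the source may have more. Where it says the series, first, only, none or still open, it means among the compounds named here.

Working notes on the series.

Compound 3 `CC(C)(C)Cc1cnc(CCc2ccc(-c3cccc(F)c3C(=O)O)cc2)n1CCC(=O)O` carries a free carboxylic acid on the biaryl and a 2-carboxyethyl chain on the core shared with compound 1 `COC(=O)c1c(F)cccc1-c1ccc(CCc2ncc(CC(C)(C)C)n2CCC(=O)O)cc1` and compound 2 `COC(=O)c1c(F)cccc1-c1ccc(CCc2ncc(CC(C)(C)C)n2CCO)cc1`. Among the compounds with values here, in an assay on cells for agonist activity at Bombesin receptor subtype-3 (Mus musculus), read by HTRF and inositol phosphate accumulation, with a stated time of 1 h (a higher number here means that more compound is needed for the effect, a lower number that less compound is needed), compound 3 gives 61 nM, the highest of the three numbers so far; compound 1 gives 3 nM and compound 2 gives 24 nM, so compound 3 sits furthest from compound 1 and closest to compound 2.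

Compound 4 `CC(C)(C)Cc1cnc(CCc2ccc(-c3cccc(F)c3C(=O)O)cc2)n1CCOc1cccc(O)c1` differs from compound 3 in one place: 3-hydroxyphenoxy in place of carboxy on a saturated chain carbon, two bonds along the chain from an aromatic nitrogen. Within the data shown here, no measured step covers this exact change. The nearest comparison is an 8.0-fold higher number from compound 1 to compound 2 (0.90 log units; beyond the scatter), where the carboxy group on the same chain was traded for a hydroxy group. The ester-to-acid step a 20-fold higher number from compound 1 to compound 3 (1.31 log units; beyond the scatter) concerns a different place and speaks only to the sensitivity of the series to changes at its acid groups.

Among the measured compounds shown here, the loss of the chain carboxy in the one measured step was modest, and the group entering here is larger and brings its own hydrogen-bond donor and acceptors; for compound 4 a loss of similar order is therefore expected, estimated at a 3.6-fold higher number from compound 3 to compound 4 (0.56 log units; beyond the scatter), beyond the scatter but not large. Compound 4 is expected to give 220 nM in this assay, with a likely range from 60 nM to 900 nM.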

Compound 4, half-maximal effective concentration: 0.8 nM
Compound 4: middle estimate off by 280-fold (2.44 log units), on the high side; measured number outside the range, below it.
By their numbers in this assay, from the lowest: compound 4; then compound 1; then compound 2; then compound 3.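

In this assay the step of a 76-fold lower number from compound 3 to compound 4 (1.88 log units; beyond the scatter) shows that the carboxy group of the 2-carboxyethyl chain is not needed for a low number: on a saturated chain carbon, two bonds along the chain from an aromatic nitrogen, 3-hydroxyphenoxy serves far better in the free-acid biaryl. Within the data shown here, the only earlier step at this place, an 8.0-fold higher number from compound 1 to compound 2 (0.90 log units; beyond the scatter) with hydroxy entering on the methyl ester biaryl, ran the opposite way, so this position can move the number in either direction, and the two steps differ in both the entering group and the biaryl substituent, which leaves those two influences unseparated. The measurements shown offer no independent data that would account for this reversal.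

Still open, on these data alone, is whether the gain comes from the aromatic ring of the 3-hydroxyphenoxy group or from its ring hydroxy, a question that a plain phenoxy group or a methoxy group in place of that hydroxy would address. Also open, as far as these compounds go, are how 3-hydroxyphenoxy behaves with the methyl ester on the biaryl, and whether a longer chain or an amine at this position fits the same trend.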